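Step from compound 2 to compound 4

A few compounds are considered here, and "the series" means these few. Any claim that something is new, unique, unknown or untested is made for them only; others in the source may bear on it.

Values in a functional assay on L1210 cells (Mus musculus) for inhibition, read by MTT assay, with a stated time of 72 h; a higher number here means a weaker inhibitor, a lower number a stronger inhibitor:
- compound 1 `COc1cc(NC(C)CCCNC(=O)NNC(=O)Nc2ccc(F)cc2)c2ncccc2c1`: 104000 nM
- compound 2 `COc1cc(NC(C)CCCNC(=O)Nc2ccc(F)cc2)c2ncccc2c1`: 18000 nM
- compound 3 `COc1cc(NC(C)CCCNC(=O)Nc2cc(C(F)(F)F)cc(C(F)(F)F)c2)c2ncccc2c1`: 3500 nM
- compound 4 `COc1cc(NC(C)CCCNC(=O)NNC(=O)Nc2cccc(Cl)c2)c2ncccc2c1`: not yet measured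

Compound 2 stands second highest of the three numbers, with compound 3 lower and compound 1 higher. The change to compound 4 is ((3-chlorophenyl)carbamoyl)amino in place of 4-fluorophenyl on an amide-type nitrogen, which puts ((3-chlorophenyl)carbamoyl)amino in place of 4-fluorophenyl on an amide-type nitrogen. Among the measured compounds shown here, the one measured step bearing on this is the reverse kind of exchange: a 5.8-fold lower number from compound 1 to compound 2 (0.76 log units; beyond the scatter). Read backwards, it leads to the expectation of a modest rise in this assay, although no measured pair isolates the 3-chlorophenyl ring. The expected step is a 3.9-fold higher number from compound 2 to compound 4 (0.59 log units; beyond the scatter). The estimated value for compound 4 is 70000 nM, with an expected range of 25000 nM to 180000 nM.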

Compound 4, half-maximal inhibitory concentration: 27000 nM
Compound 4: the middle estimate sits 2.6-fold (0.41 log units) above what was measured, within the range that was stated.
By their numbers in this assay, from the lowest: compound 3; then compounds 2 and 4 (each within the scatter of the next); then compound 1.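

In this assay the exchange on the amide-type nitrogen gives a 1.5-fold higher number from compound 2 to compound 4 (0.18 log units; within the scatter), so with a 3-chlorophenyl ring the longer ((3-chlorophenyl)carbamoyl)amino group carries no penalty beyond the scatter, unlike the 4-fluorophenyl pair in a 5.8-fold lower number from compound 1 to compound 2 (0.76 log units; beyond the scatter). The ring on the longer group also matters: the exchange of 4-fluorophenyl for 3-chlorophenyl gives a 3.9-fold lower number from compound 1 to compound 4 (0.59 log units; beyond the scatter). No evidence is available on why these steps differ. Still open, going by these compounds, is how 3-chlorophenyl behaves directly on the amide-type nitrogen without the carbamoylamino unit. Also open, on these data alone, is whether an amine or a carboxylic acid on that ring is tolerated.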